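A few compounds are considered here, and "the series" means these few. Any claim that something is new, unique, unknown or untested is made for them only; others in the source may bear on it.

Among the measured compounds shown here, in a functional assay on K562 cells (Homo sapiens) for cytotoxicity, read by trypan blue exclusion, with a stated time of 96 h (on this read-out higher numbers stand for weaker inhibition and lower numbers for stronger inhibition), compound 2 `COc1cc(OC)c(/C=C/S(=O)(=O)Cc2ccc(OC)c(N)c2)c(OC)c1` gives 2.5 nM, the lowest of the three numbers so far. Compound 1 `COc1ccc(CS(=O)(=O)/C=C/c2c(OC)cc(OC)cc2OC)c(N)c1` gives 25 nM, and compound 3 `COc1cc(OC)c(/C=C/S(=O)(=O)Cc2ccc(Cl)cc2N)c(OC)c1` gives 2500 nM.

Compound 4 `COC(=O)C(Nc1cc(CS(=O)(=O)/C=C/c2c(OC)cc(OC)cc2OC)ccc1OC)c1ccccc1` departs from compound 2 by methoxycarbonyl)(benzyl in place of hydrogen on a nitrogen on an aromatic ring. For the measured compounds named here, no measured step changes that nitrogen, so the evidence is indirect. The nearest guides are a 10-fold lower number from compound 1 to compound 2 (1.00 log units; beyond the scatter) and a 1000-fold higher number from compound 2 to compound 3 (3.00 log units; beyond the scatter), both of which alter the amino-bearing aryl group and lie beyond the scatter. The step of a 100-fold higher number from compound 1 to compound 3 (2.00 log units; beyond the scatter) shows the same sensitivity to change on this aryl group. Both compounds that differ from compound 2 sit higher, so a rise is more likely than a fall, though its size is poorly constrained.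

A moderate rise in this assay is expected, estimated as a 16-fold higher number from compound 2 to compound 4 (1.20 log units; beyond the scatter). The estimated value for compound 4 is 40 nM, with an expected range from 5 nM to 400 nM.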

Compound 4, half-maximal inhibitory concentration: 30 nM
Beside the measured number, compound 4's estimate is 1.3-fold (0.12 log units) above it; low and high end bracket the measured number.
By their numbers in this assay, from the lowest: compound 2; then compounds 1 and 4 (each within the scatter of the next); then compound 3.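

In this assay, among the compounds shown here, the nitrogen on an aromatic ring is changed here for the first time; the earlier steps altered the amino-bearing aryl group in other ways. Methoxycarbonyl)(benzyl in place of hydrogen on this nitrogen gives a 12-fold higher number from compound 2 to compound 4 (1.08 log units; beyond the scatter), beyond the scatter, so this position is sensitive to the change, yet a group of 11 heavy atoms with a six-membered aromatic ring still leaves a measurable potency. No measurement shown accounts for this rise.

A single substituted compound cannot show which part of the entering group goes with the rise. A plain methyl on this nitrogen, or a carboxylic acid in place of the methyl ester, would begin to separate those parts.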